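The source may hold more compounds than are shown below. What is called first, only, known or untested is meant among the compounds shown, and "the series" means these compounds.

Compound 3 `CC[Si](CC)(CC)C/C1=C/C[C@](C)(CCC=C(C)C)/C=C/[C@@H](OC(=O)C=C(C)C)[C@](C)(O)/C=C/C1=O` gives 3150 nM in a functional assay on MCF7 cells (Homo sapiens) for antiproliferative activity, read by MTT assay, with a stated time of 48 h (on this read-out higher numbers stand for weaker inhibition and lower numbers for stronger inhibition), the lowest of the three numbers; compound 1 `COC/C1=C/C[C@](C)(CCC=C(C)C)/C=C/[C@@H](OC(=O)C=C(C)C)[C@](C)(O)/C=C/C1=O` gives 4130 nM, within the scatter of it, while compound 2 `CC(C)=CCC[C@]1(C)/C=C/[C@@H](OC(=O)C=C(C)C)[C@](C)(O)/C=C/C(=O)/C(C=O)=C\C1` gives 12600 nM, beyond it. Compound 4 `CC(C)=CCC[C@]1(C)/C=C/[C@@H](OC(=O)C=C(C)C)[C@](C)(O)/C=C/C(=O)/C(C(=O)N2CCCC2)=C\C1` differs from compound 3 by a group of 7 heavy atoms (5 carbon, 1 nitrogen, 1 oxygen; one five-membered non-aromatic ring with 1 hetero atom) in place of a group of 8 heavy atoms (7 carbon, 1 silicon; no ring), on a double-bonded ring carbon. Two measured steps at this same ring position bear on the change: a 4.0-fold lower number from compound 2 to compound 3 (0.60 log units; beyond the scatter) and a 3.1-fold higher number from compound 1 to compound 2 (0.48 log units; beyond the scatter). Both place the formyl-bearing compound 2 at the higher number, and compound 4 likewise carries a carbonyl on that double-bonded ring carbon, so a modest rise beyond the scatter is expected, roughly undoing the drop seen in this assay on going to compound 3. Compound 4 is therefore estimated at 9000 nM, with a range of 3500 nM to 25000 nM. That expected step is a 2.9-fold higher number from compound 3 to compound 4 (0.46 log units; beyond the scatter).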

Compound 4, half-maximal inhibitory concentration: 17200 nM
Estimate against measurement, compound 4: 1.9-fold (0.28 log units) below; the measured number falls inside the stated range.
By their numbers in this assay, from the lowest: compounds 3 and 1 (each within the scatter of the next); then compounds 2 and 4 (each within the scatter of the next).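

In this assay, putting (pyrrolidin-1-yl)carbonyl on the double-bonded ring carbon gives a 5.5-fold higher number from compound 3 to compound 4 (0.74 log units; beyond the scatter) and a 4.2-fold higher number from compound 1 to compound 4 (0.62 log units; beyond the scatter), so a second compound with a carbonyl on that carbon joins the higher numbers. Formyl and (pyrrolidin-1-yl)carbonyl are not told apart here, since a 1.4-fold higher number from compound 2 to compound 4 (0.14 log units; within the scatter) stays within the scatter. Nothing available explains these differences. From the compounds shown here alone, it remains open whether a carboxylic acid on this ring carbon, or a longer chain ending in an amine, would fall with compound 2 and compound 4 or with compound 1 and compound 3.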